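The source may hold more compounds than are shown below. What is called first, only, known or untested is meant among the compounds shown, and "the series" means these compounds.

Measured compounds:
compound 1 `Nc1ncnc2c1c(-c1cnc3[nH]ccc3c1)nn2CCCC(=O)NO` — "not determined" (no result reported) in a functional assay on HeLa cells (Homo sapiens) for inhibition, read by MTT assay, with a stated time of 72 h; on this read-out higher numbers stand for weaker inhibition and lower numbers for stronger inhibition
compound 2 `Nc1nc2cc(-c3nn(CCCCCCCCC(=O)NO)c4ncnc(N)c34)ccc2o1` — 10200 nM in this assay

Compound 1 has no single number in this assay, so its own standing cannot be stated; it serves only as the starting structure. For the measured compounds named here, compound 2 is the only measured compound, and in this assay compound 2 gives 10200 nM, a weak inhibition. Going by the values given here, no step between two measured compounds exists, so the change from compound 1 to compound 3 `CNC(=O)CCCCCCCn1nc(-c2cnc3[nH]ccc3c2)c2c(N)ncnc21` can only be described: 4-(methylcarbamoyl)butyl in place of hydroxycarbamoyl on a saturated chain carbon, three bonds along the chain from an aromatic nitrogen. The group that leaves carries two hydrogen-bond donors and two acceptors; the group that enters carries one of each and a longer chain, as counted.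

With compound 2 as the only reference, the step is expected to lie beyond the usual scatter and to run toward weaker inhibition, and a limit rather than a number is a real possibility. Compound 3 is estimated at 25000 nM, within a range from 5000 nM to 120000 nM.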

Compound 3, half-maximal inhibitory concentration: 29100 nM
Compound 3: the middle estimate sits 1.2-fold (0.07 log units) below what was measured; measured number inside the range.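

In this assay, for the compounds shown here, compound 3 gives 29100 nM, but compound 1 has no single number, so no step between compound 1 and compound 3 can be read. As far as these compounds go, what replacing hydroxycarbamoyl with 4-(methylcarbamoyl)butyl does to inhibition stays open. No supporting measurement bears on this result.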